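This account rests on a few compounds, and the source may have more. Where it says the series, first, only, none or still open, it means among the compounds named here.

Measured compounds:
Compound 1 `CC12CC34CC[C@H](O)[C@@](C)(CCCO)C3C(CC1C4)O2` gives 7300 nM.
Compound 2 `CC12CC34CC[C@H](OC(=O)c5ccc(NCc6cc(O)ccc6O)cc5)[C@@](C)(CCCOC(=O)c5ccc(NCc6cc(O)ccc6O)cc5)C3C(CC1C4)O2` gives 5000 nM.
Compound 3 `O=C(O)c1ccc(NCc2cc(O)ccc2O)cc1` gives 20400 nM.

All three were tested in a functional assay on Jurkat cells (Homo sapiens) for inhibition, read by CCK-8 assay, with a stated time of 72 h; on this read-out higher numbers stand for weaker inhibition and lower numbers for stronger inhibition. Among the three numbers, compound 3 stands highest: compound 1 lies nearer to it, and compound 2 furthest, and both gaps are beyond the usual scatter of repeated measurements, so compound 3 is the weakest of the three on this read-out. Compound 2 carries two copies of the acid of compound 3 joined as esters to the core of compound 1, and its number sits below those of compound 1 and compound 3.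

Compound 4 `COC(=O)c1ccc(NCc2cc(O)ccc2O)cc1` has not yet been measured. It differs from compound 3 in one place: methyl in place of hydrogen on an oxygen next to a carbonyl group. Within the data shown here, no step between measured compounds of this kind is available, so the size of the change can only be expected, not read off. Because compound 2, where the same acid appears as an ester, gives 5000 nM, a modest move toward a lower number is expected for compound 4, of roughly a 1.9-fold lower number from compound 3 to compound 4 (0.27 log units; within the scatter) in this assay, a step that may not clear the scatter. Compound 4 is therefore estimated at 11000 nM, with a likely range from 3500 nM to 35000 nM.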

Compound 4, half-maximal inhibitory concentration: 13100 nM
For compound 4 the middle estimate is 1.2-fold (0.08 log units) below the measured one; measured number inside the range.
By their numbers in this assay, from the lowest: compounds 2, 1, 4 and 3 (each within the scatter of the next, the first and the last beyond it).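

In this assay, among these compounds, methyl in place of hydrogen on an oxygen next to a carbonyl group gives (a 1.6-fold lower number from compound 3 to compound 4 (0.19 log units; within the scatter)), the first step in this set that changes one place alone. It shows that going from carboxy to methoxycarbonyl at this position does not separate the two compounds on this read-out, so the free acid and its methyl ester cannot be told apart here. The earlier compounds shown here could not show this, since no two of them differed in one place, and the ester link in compound 2 came with the core of compound 1 and a second copy of the acid. Nothing measured here accounts for the outcome.

The compounds shown leave open whether a longer chain on this oxygen, such as ethyl or benzyl, or an amide in place of the ester, would give a step beyond the scatter. They also leave open how much of the number of compound 2 belongs to the ester links and how much to the core, as compound 2 differs from compound 1, compound 3 and compound 4 in more than one place.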